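Pyridin-3-yl replaces pyrazin-2-yl: an antiproliferative estimate

The source may report more compounds than this note shows. Statements on the series, on what has been measured and on what is new or still open speak of the compounds shown alone.

Measured compounds:
compound 1, `Cc1c(-c2cc(Cl)cc(Cl)c2)c(C(=O)O)nn1-c1nc(-c2cc(Cl)cc(Cl)c2)c(SC(C)C)s1`, 2000 nM
compound 2, `Cc1nn(-c2nc(-c3ccc(Cl)c(Cl)c3)c(SC(C)C)s2)c(C(=O)O)c1-c1cnccn1`, 14000 nM
compound 3, `Cc1c(-c2cc(Cl)cc(Cl)c2)c(C(=O)O)nn1-c1nc(-c2ccc3nccn3c2)c(SC(C)C)s1`, "not active" (no number reported)

In a functional assay on BJAB cells (Homo sapiens) for antiproliferative activity, with a stated time of 4 days (on this read-out higher numbers stand for an effect only at larger amounts of compound and lower numbers for an effect already at smaller amounts), compound 2 gives 14000 nM, the highest of the two numbers in hand; compound 1 gives a lower number, beyond the scatter, and compound 3 is reported only as not active. Compound 4, `Cc1nn(-c2nc(-c3ccc(Cl)c(Cl)c3)c(SC(C)C)s2)c(C(=O)O)c1-c1cccnc1`, has not been measured. Compared with compound 2 it shows (pyridin-3-yl in place of pyrazin-2-yl on an aromatic carbon). For the measured compounds named here, no measured pair isolates this change, so the expected step of a 1.6-fold lower number from compound 2 to compound 4 (0.19 log units; within the scatter) is taken as small, toward a lower number but not clearly beyond the scatter. On that basis compound 4 is expected to give about 9000 nM, within a range from 3000 nM to 30000 nM.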

Compound 4, half-maximal effective concentration: 12000 nM
Estimate against measurement, compound 4: 1.3-fold (0.12 log units) below; the measured number falls inside the stated range.
By their numbers in this assay, from the lowest: compound 1; then compounds 4 and 2 (each within the scatter of the next).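

In this assay, putting pyridin-3-yl in place of pyrazin-2-yl on this aromatic carbon gives a 1.2-fold lower number from compound 2 to compound 4 (0.07 log units; within the scatter) and leaves the two groups indistinguishable on this read-out. Pyridin-3-yl has fewer ring hetero atoms and hydrogen-bond acceptors, yet this difference produces no step beyond the scatter here. No measurement shown explains why the two groups read alike.

As far as these compounds go, whether an amine or a longer alkyl chain at this position would shift the number remains open. So does whether this exchange would read the same with other groups elsewhere on the core.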